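This account rests on a few compounds, and the source may have more. Where it says the series, first, only, none or still open, it means among the compounds named here.

Measured so far in a functional assay on Hep 3B2 cells (Homo sapiens) for antiproliferative activity, read by MTT assay, with a stated time of 24 h, tested at 0.14 ug/mL; a lower number here means a weaker effect, a higher number a stronger effect of the compound at the concentration tested:
- compound 1 `CCc1ccc2nc(C(=O)Nc3c(F)cc(-c4cccc(F)c4)cc3F)c(C)c(O)c2c1` gives 11.2%
- compound 2 `Cc1c(C(=O)Nc2c(F)cc(-c3cccc(F)c3)cc2F)nc2ccc(F)cc2c1O` gives 2.65%

Compound 2 stands at the lowest of the two numbers in this assay, though its nearest neighbour, compound 1, lies within the scatter of it, so no order between the two can be read from these values. Going by the values given here, the only measured step at the position in question, a number 8.6 percentage points lower from compound 1 to compound 2 (within the scatter), is within the scatter. Compound 3 `CCOc1ccc2nc(C(=O)Nc3c(F)cc(-c4cccc(F)c4)cc3F)c(C)c(O)c2c1` differs from compound 2 by ethoxy in place of fluoro on an aromatic carbon. Among the compounds with values here, no measured step brings ethoxy in at this place; the one that exchanges fluoro against ethyl there gave no change beyond the scatter. On that basis, a step no larger than the scatter is expected, a number 5.4 percentage points higher from compound 2 to compound 3 (within the scatter), leaving compound 3 near the two measured numbers. For compound 3 the expected value in this assay is 8%, with a range from 0% to 20%.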

Compound 3, a percentage reported as inhibition, at one concentration (the size of the read-out at that concentration, not a potency): 0.01%
Compound 3: middle estimate off by 8 percentage points, on the high side; low and high end bracket the measured number.
By their numbers in this assay, from the lowest: compounds 3, 2 and 1 (each within the scatter of the next, the first and the last beyond it).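

In this assay this position now yields its first step beyond the scatter: ethoxy in place of ethyl gives a number 11.2 percentage points lower from compound 1 to compound 3 (beyond the scatter) and so separates these two groups on the aromatic carbon, whereas ethoxy in place of fluoro gives a number 2.6 percentage points lower from compound 2 to compound 3 (within the scatter) and does not separate them. Fluoro therefore cannot be told apart from either ethyl or ethoxy here, and only the ethyl and ethoxy pair shows a difference. Nothing available explains that difference.

From the compounds shown here alone, whether an amine, a carboxylic acid or a longer alkoxy chain at this place would give a read-out clearly above that of the ethyl compound remains open. Going by these compounds, the three compounds share everything else, so the effect of changes elsewhere on the core or on the fluorinated aryl amide also remains open.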